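The compounds below may be only part of what the source reports. "The series", "measured", "known", "first", "only" and "open" are said of these compounds alone.

Compound 2 `COc1ccc(NC[C@H](C)NC(=O)[C@H](CC(C)C)NC(=O)c2cccc(C)c2)cc1` gives the lowest of the two numbers obtained so far in an assay on isolated protein for inhibition of cathepsin S (Homo sapiens); a lower number here means a stronger inhibitor, a higher number a weaker inhibitor. In this assay compound 2 gives 15 nM, while compound 1 `Cc1cccc(C(=O)N[C@@H](CC(C)C)C(=O)NCCN2CCc3ccccc32)c1` gives 230 nM; the gap between them is beyond the scatter. Compound 3 `COc1ccc(NC[C@@H](C)NC(=O)[C@H](CC(C)C)NC(=O)c2cccc(C)c2)cc1` has not yet been measured. Compound 3 differs from compound 2 in this way: the two compounds have the same atoms and bonds and differ only in configuration as drawn: 1 of 2 stereo elements differ; a stereocentre at a saturated chain carbon is drawn S in compound 2 and R in compound 3. Going by the values given here, no step between two measured compounds mirrors such a change, so nothing here shows how large its effect is. Changing the configuration at one centre often shifts the result, in either direction, and the shift can be small or large. Compound 3 is expected to be a weaker inhibitor than compound 2, an estimated step of a 4.0-fold higher number from compound 2 to compound 3 (0.60 log units; beyond the scatter). For compound 3 the estimated value in this assay is 60 nM, with a range from 15 nM to 250 nM.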

Compound 3, inhibition constant: 212 nM
Compound 3: middle estimate off by 3.5-fold (0.55 log units), on the low side; low and high end bracket the measured number.
By their numbers in this assay, from the lowest: compound 2; then compounds 3 and 1 (each within the scatter of the next).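

In this assay, the configuration at this saturated chain carbon matters a great deal: turning the centre from S to R gives a 14-fold higher number from compound 2 to compound 3 (1.15 log units; beyond the scatter), so the weaker inhibitor is the R form. Earlier, compounds 1 and 2 differed in more than one place, so they could not isolate the effect of any single feature; this pair can. The large shift can be tied to this single stereocentre because nothing else separates the two structures: the fact that compounds 2 and 3 differ only in the configuration as drawn.

Still open, going by these compounds, is what the second stereocentre, drawn alike in compound 2 and compound 3, contributes to the result. It is also unknown whether the preference for S would hold with a longer chain on the changed carbon, or how far an amine elsewhere on that chain would move the number.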